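Homologation of the aryl ether side chain in the EP2 series

The source may hold more compounds than are shown below. What is called first, only, known or untested is meant among the compounds shown, and "the series" means these compounds.

Compound 3 `O=C(O)c1csc([C@H]2CC[C@@H]3[C@@H](COc4ccccc4Cl)[C@H](O)C[C@@H]3O2)n1` holds the lowest number of the three measured compounds in a functional assay on CHO cells for agonist activity at prostaglandin E2 receptor EP2 subtype (Homo sapiens), read by HTRF and cAMP accumulation, with a stated time of 30 min (a higher number here means that more compound is needed for the effect, a lower number that less compound is needed), giving 3.3 nM. Compound 2 `Cc1cccc(OC[C@@H]2[C@H]3CC[C@H](c4nc(C(=O)O)cs4)O[C@H]3C[C@H]2O)c1` gives 3.6 nM, and the gap a 1.1-fold lower number from compound 2 to compound 3 (0.04 log units; within the scatter) is within the scatter, so the two are not separable. Compound 1 `O=C(O)c1csc([C@H]2CC[C@@H]3[C@@H](COc4ccc(F)cc4)[C@H](O)C[C@@H]3O2)n1` gives 7 nM, and the step of a 2.1-fold lower number from compound 1 to compound 3 (0.33 log units; beyond the scatter) is modest but beyond the scatter; a 1.9-fold lower number from compound 1 to compound 2 (0.29 log units; within the scatter) is within it.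

Compound 4 `O=C(O)c1csc([C@H]2CC[C@@H]3[C@@H](CCOc4ccccc4)[C@H](O)C[C@@H]3O2)n1` differs from compound 3 by phenoxymethyl in place of 2-chlorophenoxy on a saturated chain carbon bound to a saturated ring carbon. Within the data shown here, all three measured steps vary only the aryl group on the ether oxygen and stay small, at most modest; none lengthens the chain between the saturated ring carbon and the ether oxygen, so the step to 2-phenoxyethyl has no measured precedent. Given that aryl changes move this assay little, the expectation for compound 4 is a step of a 2.1-fold higher number from compound 3 to compound 4 (0.33 log units; beyond the scatter) of uncertain direction, with a wide range. Compound 4 is estimated at 7 nM, between 2 nM and 30 nM.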

Compound 4, half-maximal effective concentration: 1.4 nM
Beside the measured number, compound 4's estimate is 5.0-fold (0.70 log units) above it; the measured number lies below the stated range.
By their numbers in this assay, from the lowest: compound 4; then compounds 3, 2 and 1 (each within the scatter of the next, the first and the last beyond it).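

In this assay, the 2-phenoxyethyl side chain is the first at this position to stand apart from every other compound shown, with a 2.4-fold lower number from compound 3 to compound 4 (0.37 log units; beyond the scatter), a 2.6-fold lower number from compound 2 to compound 4 (0.41 log units; beyond the scatter) and a 5.0-fold lower number from compound 1 to compound 4 (0.70 log units; beyond the scatter). A longer chain between the saturated ring carbon and the ether oxygen is therefore accepted without loss, but compound 4 also carries no substituent on its phenyl ring, so these steps do not separate chain length from the aryl change. Nothing available bears on the reason for the lower number.

Open, going by these compounds, is whether 2-(2-chlorophenoxy)ethyl or the shorter unsubstituted (phenoxy)methyl side chain would assign the gain to one of the two changes. Also open, on these data alone, is how far the trend extends, for instance to a 3-phenoxypropyl chain.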